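The source may hold more compounds than are shown below. What is called first, only, known or untested is meant among the compounds shown, and "the series" means these compounds.

Measured so far:
- compound 1, `O=C(NCc1ccc(N2CCCC2)cc1)Nc1cccc2cnccc12`: in a functional assay for antagonist activity at transient receptor potential cation channel subfamily V member 1 (Homo sapiens), read by calcium flux (a lower number here means a stronger inhibitor, a higher number a weaker inhibitor), compound 1 gives 5.3 nM
- compound 2, `O=C(NCc1ccc(N2CCCCC2)cc1)Nc1cccc2cnccc12`: in this assay compound 2 gives 7.3 nM

Within the data shown here, compound 2 holds the highest of these two numbers, and its only neighbour is compound 1, with a step of a 1.4-fold higher number from compound 1 to compound 2 (0.14 log units; within the scatter) between them. Compound 3, `CC1CCN(c2ccc(CNC(=O)Nc3cccc4cnccc34)cc2)CC1`, differs from compound 2 by methyl in place of hydrogen on a saturated ring carbon. Among the measured compounds shown here, the one step measured, piperidin-1-yl in place of pyrrolidin-1-yl, stayed within the scatter, so a further small addition to that ring is expected to move the number little: a 1.2-fold higher number from compound 2 to compound 3 (0.09 log units; within the scatter). For compound 3 the estimate is 9 nM, between 3.5 nM and 25 nM.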

Compound 3, half-maximal inhibitory concentration: 9.3 nM
For compound 3 the middle estimate is 1.0-fold (0.01 log units) below the measured one; the measured number falls inside the stated range.
By their numbers in this assay, from the lowest: compounds 1, 2 and 3 (each within the scatter of the next).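

In this assay, methyl on a saturated ring carbon, three ring bonds from the ring nitrogen, gives a 1.3-fold higher number from compound 2 to compound 3 (0.11 log units; within the scatter), so this ring position accepts the added carbon with no step beyond the scatter. The full exchange of pyrrolidin-1-yl for 4-methylpiperidin-1-yl gives a 1.8-fold higher number from compound 1 to compound 3 (0.24 log units; within the scatter), so the three compounds cannot be told apart here. Nothing available explains this result. Still open, on these data alone, is how this assay responds to a longer chain, an amine or a carboxylic acid on that same ring carbon.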